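Phenyl to 4-chlorophenyl on compound 2

The source may hold more compounds than are shown below. What is called first, only, known or untested is meant among the compounds shown, and "the series" means these compounds.

In a functional assay on A549 cells (Homo sapiens) for antiproliferative activity, read by MTT assay, with a stated time of 48 h (a lower number here means a stronger inhibitor, a higher number a weaker inhibitor), compound 2 `Clc1cc2nc(-c3cn(-c4ccccc4)nc3-c3ccccc3)[nH]c2cc1Cl` gives 11100 nM and stands highest of the three numbers, with compound 3 `Fc1ccc2[nH]c(-c3cn(-c4ccccc4)nc3-c3ccc(Cl)cc3)nc2c1` at 4610 nM and compound 1 `Clc1ccc2[nH]c(-c3cn(-c4ccccc4)nc3-c3ccccc3)nc2c1` at 2370 nM both lower. Compound 4 `Clc1ccc(-c2nn(-c3ccccc3)cc2-c2nc3cc(Cl)c(Cl)cc3[nH]2)cc1` differs from compound 2 by chloro in place of hydrogen on an aromatic carbon and this is chloro in place of hydrogen on an aromatic carbon, phenyl to 4-chlorophenyl. Going by the values given here, the one measured step of this kind is modest (a 4.7-fold higher number from compound 1 to compound 2 (0.67 log units; beyond the scatter)) and it sits elsewhere on the structure. Compound 3 carries 4-chlorophenyl but has no matched partner. No step beyond the scatter is therefore expected in this assay, and the estimated step is small (a 1.1-fold higher number from compound 2 to compound 4 (0.03 log units; within the scatter)). The estimate for compound 4 is 12000 nM within an expected range (5000 nM to 30000 nM).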

Compound 4, half-maximal inhibitory concentration: 19100 nM
Compound 4: middle estimate off by 1.6-fold (0.20 log units), on the low side; the range from low to high includes it.
By their numbers in this assay, from the lowest: compounds 1 and 3 (each within the scatter of the next); then compounds 2 and 4 (each within the scatter of the next).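

In this assay, 4-chlorophenyl in place of phenyl on the core of compound 2 gives a 1.7-fold higher number from compound 2 to compound 4 (0.24 log units; within the scatter), so chloro in place of hydrogen at this position, para to a large group, leaves the number within the scatter. The earlier chloro step, a 4.7-fold higher number from compound 1 to compound 2 (0.67 log units; beyond the scatter), lay beyond the scatter, so the two sites on the series do not answer alike to this change. No measurement available gives a reason for this result. As far as these compounds go, whether an amine or a carboxylic acid at this position would move the number remains open. Also open, from the compounds shown here alone, is whether 4-chlorophenyl behaves the same way on the core of compound 1.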